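The source may hold more compounds than are shown below. What is called first, only, known or untested is meant among the compounds shown, and "the series" means these compounds.

Series notes. Going by the values given here, in a functional assay on PC-3 cells (Homo sapiens) for inhibition, read by sulforhodamine B assay, with a stated time of 48 h, tested at 10 uM (on this read-out higher numbers stand for more inhibition at the one concentration tested (going by the name of the read-out) and lower numbers for less inhibition), compound 1 `Brc1cn2ccnc2c(-c2ccc3ncn(C4CCCCC4)c3c2)n1` gives 17.2% and compound 2 `CC(=O)c1ccc(-c2cn3ccnc3c(-c3ccc4ncn(C5CCCCC5)c4c3)n2)cc1` gives 17.9%; the only single-point step measured so far, a number 0.7 percentage points higher from compound 1 to compound 2 (within the scatter), lies inside the scatter. Compound 3 `c1cn2cc(-c3ccc4c(c3)ncn4C3CCCCC3)nc(-c3ccc4ncn(C5CCCCC5)c4c3)c2n1` gives 45% in this assay, the highest of the three numbers, both other values standing lower by amounts beyond the scatter. Compound 4 `c1ccc(Cn2cnc3ccc(-c4nc(-c5ccc6c(c5)ncn6C5CCCCC5)cn5ccnc45)cc32)cc1` differs from compound 3 in one place: benzyl in place of cyclohexyl on an aromatic nitrogen. Among the compounds with values here, no measured pair in this set carries an exchange at the aromatic nitrogen, so nothing measured bears directly on this step; the one known step, a number 0.7 percentage points higher from compound 1 to compound 2 (within the scatter), concerns a different position and was within the scatter. Within the data shown here, with no relevant precedent, no step beyond the scatter is expected, and compound 4 is estimated at 40% (range 20% to 60%), the expected change being a number 5 percentage points lower from compound 3 to compound 4 (within the scatter).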

Compound 4, a percentage reported as inhibition, at one concentration (the size of the read-out at that concentration, not a potency): -39.5%
Compound 4: the middle estimate sits 79.5 percentage points above what was measured; the whole stated range lies above it.
By their numbers in this assay, from the lowest: compound 4; then compounds 1 and 2 (each within the scatter of the next); then compound 3.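

In this assay, going by these compounds alone, benzyl in place of cyclohexyl on an aromatic nitrogen gives a number 84.5 percentage points lower from compound 3 to compound 4 (beyond the scatter), the first single-place step beyond the scatter. The substituent on this nitrogen therefore matters greatly to the read-out, and compound 4 reaches a negative number, -39.5%, rather than merely a smaller inhibition. Nothing available accounts for the size of this step. Still open, as far as these compounds go, is whether a phenyl group, an isopropyl group or a longer alkyl chain on this nitrogen would give numbers nearer compound 3 or compound 4.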